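Urea aryl variation on the pyrazole series, compound 4

This account rests on a few compounds, and the source may have more. Where it says the series, first, only, none or still open, it means among the compounds named here.

Measured so far:
compound 1 `O=C(Nc1cccc(-n2cc(-c3ccncc3)c(-c3ccc(Cl)c(O)c3)n2)c1)Nc1cccc(C(F)(F)F)c1`, 1590 nM
compound 2 `COc1cc(-c2nn(-c3cccc(NC(=O)Nc4cc(C(F)(F)F)cc(C(F)(F)F)c4)c3)cc2-c2ccncc2)ccc1Cl`, 590 nM
compound 3 `COc1cc(-c2nn(-c3cccc(NC(=O)Nc4ccc(Cl)c(Cl)c4)c3)cc2-c2ccncc2)ccc1Cl`, 820 nM

The three compounds share a core and differ in the aryl group on the urea nitrogen and in the substitution of the chlorophenyl arm. In a functional assay on U-251 cells (Homo sapiens) for inhibition, read by sulforhodamine B assay, with a stated time of 48 h (a higher number here means a weaker inhibitor of growth, a lower number a stronger inhibitor of growth), compound 3 gives 820 nM, the second highest of the three numbers. Its nearest neighbour is compound 2, and the gap between the two lies within the scatter of the method; the gap to compound 1 is wider but also within the scatter. For the measured compounds named here, on these numbers no compound can be called stronger or weaker than another.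

Compound 4 `COc1cc(-c2nn(-c3cccc(NC(=O)Nc4cccc(C(F)(F)F)c4)c3)cc2-c2ccncc2)ccc1Cl` has not yet been measured. It differs from compound 3 in one place: 3-(trifluoromethyl)phenyl in place of 3,4-dichlorophenyl on an amide-type nitrogen. Going by the values given here, no pair of measured compounds shows this particular exchange, so no measured step can be carried over. All three measured values sit close together, and the change keeps the urea and its aryl ring while exchanging only the substitution pattern. The expectation for compound 4 is therefore a step from compound 3 of no more than the scatter, in either direction, estimated as a 1.1-fold higher number from compound 3 to compound 4 (0.04 log units; within the scatter). Compound 4 is expected to give about 900 nM, within a range of 400 nM to 2000 nM.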

Compound 4, concentration for 50% growth inhibition: 645 nM
Compound 4: middle estimate off by 1.4-fold (0.14 log units), on the high side; the measured number falls inside the stated range.
By their numbers in this assay, from the lowest: compounds 2, 4, 3 and 1 (each within the scatter of the next, the first and the last beyond it).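

In this assay the urea aryl position now has two readable exchanges: 3-(trifluoromethyl)phenyl in place of 3,4-dichlorophenyl on the amide-type nitrogen gives a 1.3-fold lower number from compound 3 to compound 4 (0.10 log units; within the scatter) and hydrogen in place of trifluoromethyl on an aromatic carbon gives a 1.1-fold higher number from compound 2 to compound 4 (0.04 log units; within the scatter), so neither change moves the number beyond the scatter. For the compounds shown here, compound 4 also links the series to compound 1 through a change outside the urea aryl group: methyl in place of hydrogen on an oxygen on an aromatic ring gives a 2.5-fold lower number from compound 1 to compound 4 (0.39 log units; beyond the scatter), the only step so far beyond the scatter, modest in size and resting on this single pair. Nothing measured here gives a reason for any of these steps.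

Still open, going by these compounds, is whether the step at the oxygen holds when the urea carries another aryl group, such as 3,4-dichlorophenyl, or when a longer chain such as ethyl stands on that oxygen. It is equally open how the urea aryl position responds to an amine or a carboxylic acid on the ring, since the aryl groups shown carry only chlorine or trifluoromethyl.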